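Replacing a methoxy with butyl on a nucleoside analogue

A few compounds are considered here, and "the series" means these few. Any claim that something is new, unique, unknown or untested is made for them only; others in the source may bear on it.

Compound 1, `CC1(C)[C@@H](Cn2nnc3c(N)nc(N)nc32)CC[C@@]1(C)CO`: > 200000 nM (a limit)
Compound 2, `COCC#Cc1cn([C@H]2C[C@H](O)[C@@H](CO)O2)c(=O)[nH]c1=O`: > 200000 nM (a limit)
Compound 3, `CC1(C)[C@@H](CCCO)C[C@H]1n1nnc2c(N)nc(N)nc21`: > 200000 nM (a limit)

In an ADME assay on L1210/0 cells (Mus musculus) for cytotoxicity, with a stated time of 48 h (a lower number here means a stronger inhibitor, a higher number a weaker inhibitor), compound 1 reaches only a limit, > 200000 nM. Compound 2 likewise gives only a limit in this assay, namely > 200000 nM. Compound 3 also stays at a limit, > 200000 nM. So compound 2 stands where every measured value stands, because of the limit of > 200000 nM in this assay, at which 3 of the 3 values shown sit. For the measured compounds named here, no step between two measured numbers exists to show what any structural change does here.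

Compound 4, `CCCCCC#Cc1cn([C@H]2C[C@H](O)[C@@H](CO)O2)c(=O)[nH]c1=O`, differs from compound 2 in one place: butyl in place of methoxy on a saturated chain carbon bound to a triple-bonded carbon. Going by the values given here, with no measured step to lean on, compound 4 is expected to behave like compound 2, so the step of a number no higher from compound 2 to compound 4 (the limit leaves the size open) is estimated as none beyond the scatter. Compound 4 is therefore expected to give about 200000 nM, within 50000 nM to 500000 nM.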

Compound 4, half-maximal inhibitory concentration: > 200000 nM
Compound 4 gave a limit, no number (the forecaster's own chance of this, stated with the estimate: 80%); the middle value sits exactly at the limit.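

No step can be read between compound 2 and compound 4, because both stop at a limit rather than a number: the limit of > 200000 nM in this assay, at which 4 of the 4 values shown sit.

The compounds shown leave open whether butyl in place of methoxy changes anything in this assay.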